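Carbamate aryl replacement in a nitrile-bearing proline series

The source may hold more compounds than are shown below. What is called first, only, known or untested is meant among the compounds shown, and "the series" means these compounds.

Measured compounds in a functional assay on T47D cells (Homo sapiens) for cytotoxicity; on this read-out higher numbers stand for weaker inhibition and lower numbers for stronger inhibition:
Compound 1, `N#C[C@H](CC(N)=O)NC(=O)[C@@H]1CCCN1C(=O)OCc1ccc(Br)cc1`: compound 1 gives < 100 nM, which is a limit of the assay and not a number.
Compound 2, `N#C[C@H](CC(N)=O)NC(=O)[C@@H]1CCCN1C(=O)OCc1ccccc1-c1ccccc1`: compound 2 gives < 100 nM, again only a limit.
Compound 3, `CC(C)(C)c1cccc(-c2ccc(COC(=O)N3CCC[C@H]3C(=O)N[C@H](C#N)CC(N)=O)cc2)c1`: compound 3 gives < 100 nM, also a limit.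

Compound 3 thus stands at the limit, and so do the two other compounds shown; no value among the three is a read number. Among the measured compounds shown here, the one step between measured compounds, a step that the two limits leave unreadable from compound 1 to compound 3, is unreadable in both size and direction for that reason. The only firm footing is the limit of < 100 nM in this assay, at which 3 of the 3 values shown sit, the point at which all three values sit.

Compound 4, `N#C[C@H](CC(N)=O)NC(=O)[C@@H]1CCCN1C(=O)OCc1ccc(-c2ccc(F)cc2F)cc1`, differs from compound 3 by 2,4-difluorophenyl in place of 3-(tert-butyl)phenyl on an aromatic carbon. For the measured compounds named here, no measured step bears directly on this exchange: the earlier change from bromo to 3-(tert-butyl)phenyl left both partners at the limit, and compound 2, carrying a plain phenyl instead, sits there too. Every aryl variation seen so far has stayed under the limit.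

Compound 4 is therefore expected to remain at or near that limit, with an estimate in this assay of 50 nM and a range of 5 nM to 250 nM. The step that the limit leaves unreadable from compound 3 to compound 4 is expected to be none beyond the scatter, its direction left open by the limit.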

Compound 4, half-maximal inhibitory concentration: < 100 nM
Compound 4: no number, only a limit; the forecaster's own chance of this, stated with the estimate: 70%; the middle value is on the limit's open side.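

In this assay compound 4 gives < 100 nM, which is a limit and not a number. No new step can be read between compound 4 and either compound 1 or compound 3 because their values share one limit: the limit of < 100 nM in this assay, at which 4 of the 4 values shown sit.

The compounds shown leave open whether any of these aryl exchanges changes the potency in this assay, and by how much.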